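A methyl-to-methoxy swap on the lowest-scoring compound

A few compounds are considered here, and "the series" means these few. Any claim that something is new, unique, unknown or untested is made for them only; others in the source may bear on it.

Going by the values given here, in a functional assay on the whole organism (strain Wistar albino) for inhibition, with Rattus norvegicus as the target, read by paw edema, with stated times of 1 h and 3 h, at a dose of 0.32 mmol/kg by the intraperitoneal route (a higher number here means more inhibition at the dose given (going by the name of the read-out), a lower number less inhibition), compound 1 `COc1ccc(/N=C\c2cn(-c3ccc(Cl)cc3)nc2-c2ccc(OC)cc2)cc1` gives 82.2% and compound 2 `COc1ccc(-c2nn(-c3ccc(Cl)cc3)cc2/C=N\c2ccc(Cl)cc2)cc1` gives 72.6%; the only single change measured, a number 9.6 percentage points lower from compound 1 to compound 2 (within the scatter), leaves the number essentially where it was. Compound 3 `COc1ccc(-c2[nH]c(-c3ccc(Cl)cc3)cc2-c2cn(-c3ccc(Cl)cc3)nc2-c2ccc(C)cc2)cc1` stands lowest of the three in this assay with 21.3%, a gap to both others that the scatter does not cover. Compound 4 `COc1ccc(-c2nn(-c3ccc(Cl)cc3)cc2-c2cc(-c3ccc(Cl)cc3)[nH]c2-c2ccc(OC)cc2)cc1` differs from compound 3 only in methoxy in place of methyl on an aromatic carbon. Among the compounds with values here, the one measured step that bears on such a para-group exchange, a number 9.6 percentage points lower from compound 1 to compound 2 (within the scatter), stayed within the scatter, so no shift beyond the scatter is expected in this assay for a number 2.7 percentage points higher from compound 3 to compound 4 (within the scatter). Compound 4 is therefore estimated at 24%, between 8% and 42%.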

Compound 4, a percentage reported as inhibition, in the whole organism at one dose (the size of the read-out at that dose, not a potency): 20.7%
Compound 4: the middle estimate sits 3.3 percentage points above what was measured, within the range that was stated.
By their numbers in this assay, from the lowest: compounds 4 and 3 (each within the scatter of the next); then compounds 2 and 1 (each within the scatter of the next).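

In this assay the exchange of 4-methylphenyl for 4-methoxyphenyl gives a number 0.6 percentage points lower from compound 3 to compound 4 (within the scatter). The earlier step put chloro in place of methoxy in another pair; this one shows that, on this ring, para to a large group, methyl and methoxy cannot be told apart by this read-out. Nothing at hand explains this result. The compounds shown leave open whether an amine or a carboxylic acid on this carbon would shift the number beyond the scatter.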